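From compound 3 to compound 4: a new chain end

The source may report more compounds than this note shows. Statements on the series, on what has been measured and on what is new or still open speak of the compounds shown alone.

Compound 1 `O=C1C=CC(O)(c2cc3ccccc3n2S(=O)(=O)c2ccccc2)C=C1` in an ADME assay on MRC5 cells (Homo sapiens) for cytotoxicity, read by fluorescence and resazurin assay, with a stated time of 3 days (on this read-out lower numbers stand for an effect already at smaller amounts and higher numbers for an effect only at larger amounts of compound), gives 110 nM
Compound 2 `COC(=O)CCc1ccc(S(=O)(=O)n2c(C3(O)C=CC(=O)C=C3)cc3ccccc32)cc1` in this assay gives 280 nM
Compound 3 `O=C1C=CC(O)(c2cc3ccccc3n2S(=O)(=O)c2ccc(CCCO)cc2)C=C1` in this assay gives 51 nM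

Compound 3 (51 nM) holds the lowest number of the three, and its steps to both others lie beyond the scatter. Compound 4 `O=C1C=CC(O)(c2cc3ccccc3n2S(=O)(=O)c2ccc(CCC(=O)N3CCOCC3)cc2)C=C1` differs from it by (morpholin-4-yl)carbonyl in place of hydroxymethyl on a saturated chain carbon, two bonds along the chain from an aromatic carbon with (morpholin-4-yl)carbonyl in place of hydroxymethyl on a saturated chain carbon, two bonds along the chain from an aromatic carbon. The closest measured change sits at that same place and swaps methoxycarbonyl for hydroxymethyl, giving a 5.5-fold lower number from compound 2 to compound 3 (0.74 log units; beyond the scatter) as a modest step. The two chains on the core of compound 1 moved the number in opposite directions (a 2.5-fold higher number from compound 1 to compound 2 (0.41 log units; beyond the scatter) and a 2.2-fold lower number from compound 1 to compound 3 (0.33 log units; beyond the scatter)). Among the compounds with values here, no compound carrying (morpholin-4-yl)carbonyl has been measured. The step expected in this assay is upward, estimated as a 3.7-fold higher number from compound 3 to compound 4 (0.57 log units; beyond the scatter) by analogy with the methoxycarbonyl chain. Compound 4 is estimated at 190 nM (70 nM to 500 nM).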

Compound 4, half-maximal effective concentration: 67 nM
Beside the measured number, compound 4's estimate is 2.8-fold (0.45 log units) above it; the measured number lies below the stated range.
By their numbers in this assay, from the lowest: compounds 3, 4 and 1 (each within the scatter of the next, the first and the last beyond it); then compound 2.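

In this assay the exchange of hydroxymethyl for (morpholin-4-yl)carbonyl on this saturated chain carbon gives a 1.3-fold higher number from compound 3 to compound 4 (0.12 log units; within the scatter) and so leaves the number level with the alcohol chain. Adding the whole 2-((morpholin-4-yl)carbonyl)ethyl group to the core of compound 1 gives a 1.6-fold lower number from compound 1 to compound 4 (0.22 log units; within the scatter) and likewise leaves the number level. A carbonyl at this chain end therefore does not by itself bring the higher number of compound 2, as morpholin-4-yl in place of methoxy gives a 4.2-fold lower number from compound 2 to compound 4 (0.62 log units; beyond the scatter) and shows that the group on the carbonyl carbon matters.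

On these data alone, whether a carboxylic acid, an amine or a longer chain here would stay level with compound 3 and compound 4 remains open. Nothing available explains why the methoxycarbonyl chain stands apart from the morpholine amide chain.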